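Fluoro to cyano on a small antiproliferative series

A few compounds are considered here, and "the series" means these few. Any claim that something is new, unique, unknown or untested is made for them only; others in the source may bear on it.

- Compound 1 `O=C(N/N=C/c1ccccc1)Nc1ccc(Oc2ccnc3[nH]ccc23)c(F)c1` gives 7940 nM
- Compound 2 `O=C(N/N=C/c1ccc(Br)cc1)Nc1ccc(Oc2ccnc3[nH]ccc23)c(F)c1` gives 920 nM
- Compound 3 `O=C(N/N=C/c1ccc(F)cc1)Nc1ccc(Oc2ccnc3[nH]ccc23)c(F)c1` gives 2330 nM

These values come from a functional assay on PC-3 cells (Homo sapiens) for antiproliferative activity, read by MTT assay, with a stated time of 72 h (on this read-out lower numbers stand for stronger inhibition and higher numbers for weaker inhibition), where compound 3 holds the middle place: its number sits above that of compound 2 and below that of compound 1. Compound 4 `N#Cc1ccc(/C=N/NC(=O)Nc2ccc(Oc3ccnc4[nH]ccc34)c(F)c2)cc1` has not yet been measured. It keeps the rest of compound 3 and changes a single group, from 4-fluorophenyl to 4-cyanophenyl: cyano in place of fluoro on an aromatic carbon. In short, the fluoro group gives way to cyano, para to a large group.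

Among the compounds with values here, three measured steps bear on this change. Fluoro in place of hydrogen gave a 3.4-fold lower number from compound 1 to compound 3 (0.53 log units; beyond the scatter), and bromo in place of hydrogen gave an 8.6-fold lower number from compound 1 to compound 2 (0.94 log units; beyond the scatter). Exchanging bromo for fluoro gave a 2.5-fold higher number from compound 2 to compound 3 (0.40 log units; beyond the scatter). Within the data shown here, both groups lowered the number, but neither is cyano, and no measured compound carries it. A small shift toward a lower number in this assay therefore seems the fair expectation, and it may not pass beyond the scatter. The estimated step is a 1.6-fold lower number from compound 3 to compound 4 (0.19 log units; within the scatter). Compound 4 is expected at 1500 nM, within an estimated range of 500 nM to 4500 nM.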

Compound 4, half-maximal inhibitory concentration: 9030 nM
Estimate against measurement, compound 4: 6.0-fold (0.78 log units) below; the measured number lies above the stated range.
By their numbers in this assay, from the lowest: compound 2; then compound 3; then compounds 1 and 4 (each within the scatter of the next).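

In this assay, the position para to a large group does not reward every replacement of hydrogen: cyano gives a 1.1-fold higher number from compound 1 to compound 4 (0.06 log units; within the scatter) and so stays level with the unsubstituted parent, while fluoro and bromo had both brought the number down. Within the data shown here, the choice of group therefore matters more at this position than the earlier compounds could show, since putting cyano in place of fluoro gives a 3.9-fold higher number from compound 3 to compound 4 (0.59 log units; beyond the scatter) and putting cyano in place of bromo gives a 9.8-fold higher number from compound 2 to compound 4 (0.99 log units; beyond the scatter) with the whole gain from either halogen gone in both cases. Nothing available here accounts for why cyano parts from fluoro and bromo in this way.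

On these data alone, with only four groups at this position, it remains open whether the lower numbers belong to halogens alone or would also appear with a chloro, methyl, methoxy or trifluoromethyl group in the same place. As far as these compounds go, it also remains open whether a close relative of cyano, such as an amide or a carboxylic acid, would stay level with compound 1 as compound 4 does or would behave more like compound 2 and compound 3.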